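The compounds below may be only part of what the source reports. "The series", "measured", "known", "first", "only" and "open" are said of these compounds alone.

Compound 1, `C=C(Br)C(=O)Nc1ccc(/C=C2\SC(=O)N(Cc3ccc(Cl)cc3)C2=O)cc1`, gives 3400 nM in a functional assay on L1210 cells (Mus musculus) for cytotoxicity, read by cell counting, with a stated time of 2 days; a higher number here means a weaker inhibitor, a lower number a stronger inhibitor.
Compound 2, `C=C(Br)C(=O)Nc1ccc(/C=C2\SC(=O)N(Cc3ccc(C(C)(C)C)cc3)C2=O)cc1`, gives 1600 nM in this assay.
Compound 3, `C=C(Br)C(=O)Nc1cccc(/C=C2\SC(=O)N(Cc3ccc(Cl)cc3)C2=O)c1`, gives 940 nM in this assay.

Compounds 1 and 3 share the same atoms joined differently; the difference between the two cores is not broken down here. Compound 2 differs from compound 1 by tert-butyl in place of chloro on an aromatic carbon, and this change gives a 2.1-fold lower number from compound 1 to compound 2 (0.33 log units; beyond the scatter). Compound 4, `C=C(Br)C(=O)Nc1cccc(/C=C2\SC(=O)N(Cc3ccc(C(C)(C)C)cc3)C2=O)c1`, is not yet measured; it differs from compound 3 by tert-butyl in place of chloro on an aromatic carbon, the same change at the same place as from compound 1 to compound 2. In this assay, among the compounds with values here, the step is expected to repeat, resting on the single measured pair, and the estimate is a 2.0-fold lower number from compound 3 to compound 4 (0.30 log units; within the scatter). Compound 4 is therefore expected to give about 470 nM, most likely between 250 nM and 900 nM.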

Compound 4, half-maximal inhibitory concentration: 3200 nM
The estimate for compound 4 lay 6.8-fold (0.83 log units) below the measured number, outside the stated range (above it).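

In this assay tert-butyl in place of chloro gave a 3.4-fold higher number from compound 3 to compound 4 (0.53 log units; beyond the scatter) and thus did not repeat the earlier step, as the two steps ran in opposite directions: the same change on two cores in this assay, a 2.1-fold lower number (0.33 log units; beyond the scatter) from compound 1 to compound 2 and a 3.4-fold higher number (0.53 log units; beyond the scatter) from compound 3 to compound 4, 7.2-fold (0.86 log units) apart, beyond the scatter of two such steps. In these two pairs, the outcome of this change therefore depends on the core it is made on, so a step measured on the core of compound 1 cannot simply be carried to the core of compound 3. The two pairs do not show why the cores differ, nor how the change would behave on any other core.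

The compounds shown leave open how a methoxy group or an amine in place of chloro would behave on each core. They also leave open whether the two cores would part in the same way for such groups.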